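From Fluoro to Methyl on an Aromatic Carbon

A few compounds are considered here, and "the series" means these few. Any claim that something is new, unique, unknown or untested is made for them only; others in the source may bear on it.

Of the compounds shown here, two have been measured so far in an ADME assay on a cell-free system (plasma, Mus musculus); a lower number here means a smaller unbound share, a higher number a larger unbound share of the compound. Compound 1 (`Cc1ccc(S(=O)(=O)N(C)C(C)C)cc1C#Cc1cc(Cl)ccc1OCC(=O)O`) gives 0.005, and compound 2 (`CS(=O)(=O)c1ccc(F)c(C#Cc2cc(Cl)ccc2OCC(=O)O)c1`) gives 0.054, the higher number, with a gap beyond the scatter. Compound 3 (`Cc1ccc(S(C)(=O)=O)cc1C#Cc1cc(Cl)ccc1OCC(=O)O`) has methyl in place of fluoro on an aromatic carbon, ortho to a large group and para to a methylsulfonyl group: methyl in place of fluoro on an aromatic carbon. Within the data shown here, no measured pair shows this swap alone, so only a rough expectation is possible. A small fall is expected, a 1.8-fold lower number from compound 2 to compound 3 (0.26 log units; within the scatter), probably within the scatter of this assay. For compound 3 the estimated value is 0.03, with an expected range of 0.012 to 0.07.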

Compound 3, unbound fraction: 0.027
Compound 3: the middle estimate sits 1.1-fold (0.05 log units) above what was measured; the range from low to high includes it.
By their numbers in this assay, from the lowest: compound 1; then compounds 3 and 2 (each within the scatter of the next).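

In this assay, methyl in place of fluoro on this aromatic carbon gives a 2.0-fold lower number from compound 2 to compound 3 (0.30 log units; within the scatter), so the two groups cannot be told apart here. The sulfonyl sulfur behaves differently: methyl in place of isopropyl(methyl)amino gives a 5.4-fold higher number from compound 1 to compound 3 (0.73 log units; beyond the scatter), a step that clears the scatter. Nothing available explains either result. On these data alone, whether an amine or a methoxy group on the same aromatic carbon would also leave the unbound fraction within the scatter of compound 2 remains open.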